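The source may report more compounds than this note shows. Statements on the series, on what has been measured and on what is new or still open speak of the compounds shown alone.

Measured in a physicochemical assay for lipophilicity, using the shake flask method, in phosphate buffer, measured as octanol-water partition, with a stated time of 24 h, at pH 7.4, tested at 100 uM; on this read-out lower numbers stand for lower lipophilicity and higher numbers for higher lipophilicity:

- compound 1 `Cc1cccc(C)c1-c1cccc(COc2ccc(S(=O)(=O)CC(=O)O)cc2)c1` gives 2.49
- compound 2 `CCOc1cc(C)c(-c2cccc(COc3ccc(S(=O)(=O)CC(=O)O)cc3)c2)c(C)c1` gives 2.86
- compound 3 `Cc1cc(OCC2CC2)cc(C)c1-c1cccc(COc2ccc(S(=O)(=O)CC(=O)O)cc2)c1` gives 3.46

Compound 1 stands lowest of these three. Its nearest neighbour is reached by a number 0.37 log units higher from compound 1 to compound 2 (beyond the scatter), and its furthest by a number 0.97 log units higher from compound 1 to compound 3 (beyond the scatter). Going on from ethoxy to cyclopropylmethoxy gives a number 0.60 log units higher from compound 2 to compound 3 (beyond the scatter).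

The compound still to be measured is compound 4 `O=C(O)CS(=O)(=O)c1ccc(OCc2cccc(-c3ccccc3Cl)c2)cc1`. It swaps one group of compound 1: 2-chlorophenyl in place of 2,6-dimethylphenyl on an aromatic carbon. In words, 2-chlorophenyl stands in place of 2,6-dimethylphenyl on an aromatic carbon.

For the measured compounds named here, no measured compound carries chlorine, so no step here tests this swap directly. The three steps bear on it only loosely. Each one, such as a number 0.97 log units higher from compound 1 to compound 3 (beyond the scatter), adds an ethoxy or cyclopropylmethoxy group or enlarges one, and all three raise the number in this assay. The swap in compound 4 adds nothing of that kind, so these steps give no reason to expect a rise of similar size. With one group of similar size replacing another, a small fall seems most likely, though it may stay within the scatter.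

The estimated change is a number 0.19 log units lower from compound 1 to compound 4 (within the scatter). For compound 4 the expected value is 2.3, with an estimated range from 1.9 to 2.7.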

Compound 4, distribution coefficient: 2.47
Compound 4: middle estimate off by 0.17 log units, on the low side, and the stated range covers the measured number.
By their numbers in this assay, from the lowest: compounds 4 and 1 (each within the scatter of the next); then compound 2; then compound 3.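

Replacing 2,6-dimethylphenyl with 2-chlorophenyl on an aromatic carbon, at a place meta to a large group, gives a number 0.02 log units lower from compound 1 to compound 4 (within the scatter) in this assay, so this read-out does not separate the two compounds. The earlier steps shown here only added or enlarged an ether group on the ring, and each moved the number beyond the scatter. This step exchanges the whole ring group, with 8 heavy atoms of carbon leaving and 7 heavy atoms entering, 6 of carbon and 1 of chlorine, and shows that such an exchange at this place can leave the number within the scatter. No measurement shown here explains why these two groups give numbers so close together.

Still open, from the compounds shown here alone, is how plain phenyl, with neither chlorine nor methyl, or a phenyl ring carrying an amine, would read in this assay at this place. Also open, going by these compounds, is whether adding ethoxy or cyclopropylmethoxy to the 2-chlorophenyl ring would raise the number as it does on the 2,6-dimethylphenyl ring.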